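The source may hold more compounds than are shown below. What is called first, only, known or untested is meant among the compounds shown, and "the series" means these compounds.

Measured so far:
Compound 1, `O=C(CCSc1nnc(-c2ccncc2)s1)NCc1ccccc1Cl`. In an ADME assay on HepG2 cells (Homo sapiens) for cytotoxicity, with a stated time of 3 days (a lower number here means that less compound is tolerated, a higher number that more compound is tolerated), compound 1 gives a limit of the assay, not a number: > 50000 nM.
Compound 2, `O=C(CCSc1nnc(-c2ccncc2)s1)NCc1ccccc1`. Compound 2 gives 14000 nM.
Compound 3, `CC(CSc1nnc(-c2ccncc2)s1)C(=O)Nc1ccccc1`. Compound 3 gives a limit, not a number: > 50000 nM.

All three share the same core and differ only in the outer part. Compound 1 differs from compound 2 by chloro in place of hydrogen on an aromatic carbon; that change gives an at least 3.5-fold higher number from compound 2 to compound 1 (0.55 log units; beyond the scatter). Compound 3 is built from the same atoms as compound 2, joined differently; the difference between the two cores is not broken down here.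

Compound 4, `CC(CSc1nnc(-c2ccncc2)s1)C(=O)Nc1ccccc1Cl`, is not yet measured. It differs from compound 3 by chloro in place of hydrogen on an aromatic carbon, the same change as from compound 2 to compound 1, at a place described in the same words.

Since compound 3 already sits at > 50000 nM and the earlier step of an at least 3.5-fold higher number from compound 2 to compound 1 (0.55 log units; beyond the scatter) raised the number, compound 4 is expected to sit at or beyond the limit of > 50000 nM in this assay, at which 2 of the 3 values shown sit, as well. The expected step is a step that the limit leaves unreadable from compound 3 to compound 4. The estimate for compound 4 is 60000 nM, between 30000 nM and 120000 nM.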

Compound 4, half-maximal cytotoxic concentration: > 50000 nM
Compound 4: a limit, no number; the forecaster's own chance of this, stated with the estimate: 80%; the middle value lies beyond the limit too.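

Compound 3 and compound 4 both give a limit rather than a number in this assay, so no step can be read between them, because neither value can be placed exactly: the limit of > 50000 nM in this assay, at which 3 of the 4 values shown sit.

The compounds shown leave open how far beyond that limit each compound lies, and whether swapping phenyl for 2-chlorophenyl changes the number in this pair at all.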